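Indole nitrogen substituent swap on the shared core

The source may hold more compounds than are shown below. What is called first, only, known or untested is meant among the compounds shown, and "the series" means these compounds.

Compound 1 `N#Cc1c(-c2ccc3c(ccn3CC3CC3)c2)ccn2c(CC(F)(F)F)cnc12` gives 190 nM in a functional assay on CHO cells for agonist activity at metabotropic glutamate receptor 2 (Homo sapiens), read by GTPgammaS binding (a higher number here means that more compound is needed for the effect, a lower number that less compound is needed), and stands at the lowest of the two numbers seen so far. Compound 2 `N#Cc1c(-c2ccc3c(c2)OCCN3)ccn2c(CC(F)(F)F)cnc12` gives 1660 nM in this assay. The next change to compound 1 is 4-hydroxycyclohexyl in place of cyclopropylmethyl on an aromatic nitrogen, yielding compound 3 `N#Cc1c(-c2ccc3c(ccn3[C@H]3CC[C@H](O)CC3)c2)ccn2c(CC(F)(F)F)cnc12`. For the measured compounds named here, no measured pair shows this exchange, so the size of the step is unknown. For compound 3 a modest rise in this assay is expected, within or just beyond the scatter, the expected step being a 1.6-fold higher number from compound 1 to compound 3 (0.20 log units; within the scatter). Compound 3 is estimated at 300 nM, with a range from 80 nM to 1200 nM.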

Compound 3, half-maximal effective concentration: 330 nM
Compound 3: middle estimate off by 1.1-fold (0.04 log units), on the low side, and the stated range covers the measured number.
By their numbers in this assay, from the lowest: compounds 1 and 3 (each within the scatter of the next); then compound 2.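

On an aromatic nitrogen of a five-membered aromatic ring, 4-hydroxycyclohexyl in place of cyclopropylmethyl gives a 1.7-fold higher number from compound 1 to compound 3 (0.24 log units; within the scatter) in this assay on the shared core. This position therefore takes a six-membered non-aromatic ring bearing a hydrogen-bond donor and acceptor, with two defined stereocentres, and the number stays within the scatter. Nothing on hand bears on why the two substituents read alike. Open, on these data alone, is whether plain cyclohexyl, an amine in place of the hydroxyl, or a longer chain on this nitrogen reads the same. As far as these compounds go, the other stereoisomer of 4-hydroxycyclohexyl is also open.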